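Amide variation on a shared core against sodium channel type 3

The source may hold more compounds than are shown below. What is called first, only, known or untested is meant among the compounds shown, and "the series" means these compounds.

Compound 1, `CC(C)(C)OC(=O)n1cc(-c2ccc(NC(=O)c3ccc[nH]3)cc2)nc1N`: in an assay on isolated protein for inhibition of sodium channel protein type 3 subunit alpha (Homo sapiens), read by electrophysiology, with a stated time of 4 min (a lower number here means a stronger inhibitor, a higher number a weaker inhibitor), a limit, > 30000 nM
Compound 2, `CC(C)(C)OC(=O)n1cc(-c2ccc(NC(=O)c3ccco3)cc2)nc1N`: 27000 nM
Compound 3, `CC(C)(C)OC(=O)n1cc(-c2ccc(NC(=O)c3cc4ccccc4[nH]3)cc2)nc1N`: 22000 nM

Compound 3 holds the lowest of the two numbers, separated from compound 2 by a 1.2-fold lower number from compound 2 to compound 3 (0.09 log units; within the scatter), a gap within the scatter; the value of compound 1 is a limit (the limit of > 30000 nM in this assay, at which 1 of the 3 values shown sits). Compound 4, `CC(C)(C)OC(=O)n1cc(-c2ccc(NC(=O)[C@@H]3CCCN3)cc2)nc1N`, differs from compound 3 by pyrrolidin-2-yl in place of 1H-indol-2-yl on a carbonyl carbon. The comparable steps, an at least 1.1-fold lower number from compound 1 to compound 2 (0.04 log units; that floor lies within the scatter) and an at least 1.3-fold lower number from compound 1 to compound 3 (0.13 log units; that floor lies within the scatter), exchanged groups on the same carbonyl carbon and stayed within the scatter, so no step beyond the scatter is expected here. Compound 4 is therefore estimated at 25000 nM, between 8000 nM and 60000 nM, a step of a 1.1-fold higher number from compound 3 to compound 4 (0.06 log units; within the scatter) that is expected to be within the scatter.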

Compound 4, half-maximal inhibitory concentration: 25000 nM
Compound 4: middle estimate and measured number agree at the digits printed; low and high end bracket the measured number.
By their numbers in this assay, from the lowest: compounds 3, 4 and 2 (each within the scatter of the next). At a limit, above all of these: compound 1.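

In this assay, pyrrolidin-2-yl, the only non-aromatic ring shown on this carbonyl carbon, stays within the scatter of both aromatic groups it can be compared with (a 1.1-fold higher number from compound 3 to compound 4 (0.06 log units; within the scatter); a 1.1-fold lower number from compound 2 to compound 4 (0.03 log units; within the scatter)). Against compound 1, only a floor can be read (an at least 1.2-fold lower number from compound 1 to compound 4 (0.07 log units; that floor lies within the scatter)). Compound 1 is a limit: the limit of > 30000 nM in this assay, at which 1 of the 4 values shown sits.

Going by these compounds, whether an amine on a longer chain or a carboxylic acid on this carbonyl carbon would give a step beyond the scatter remains open. Also open, on these data alone, is how the opposite stereocentre of pyrrolidin-2-yl would compare.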